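A Second Trimethoxyphenyl Group for Compound 4

The source may report more compounds than this note shows. Statements on the series, on what has been measured and on what is new or still open speak of the compounds shown alone.

Measured in a functional assay on NCI-H322M cells (Homo sapiens) for inhibition; a lower number here means a stronger inhibitor of growth, a higher number a weaker inhibitor of growth:
compound 1, `COc1cc(/C=C/C(=O)c2cccc(-n3cc(-c4ccccc4)[nH]c3=O)c2)ccc1O`, gives 3390 nM
compound 2, `O=C(/C=C/c1cccc(O)c1)c1cccc(-n2cc(-c3ccccc3)[nH]c2=O)c1`, gives 10600 nM
compound 3, `COc1cc(/C=C/C(=O)c2cccc(-n3cc(-c4ccccc4)[nH]c3=O)c2)cc(OC)c1OC`, gives 2020 nM

Compound 3 holds the lowest of the three numbers in this assay, yet its gap to compound 1 lies within the scatter, so the two cannot be ranked; only compound 2 stands clearly apart from it. Among the compounds with values here, the one measured step, a 3.1-fold higher number from compound 1 to compound 2 (0.50 log units; beyond the scatter), concerns the aryl group on the double-bonded chain and not the five-membered aromatic ring with 2 nitrogen.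

Compound 4, `COc1cc(/C=C/C(=O)c2cccc(-n3cc(-c4cc(OC)c(OC)c(OC)c4)[nH]c3=O)c2)cc(OC)c1OC`, differs from compound 3 by 3,4,5-trimethoxyphenyl in place of phenyl on an aromatic carbon. Within the data shown here, no measured step touches this position, so nothing in the data speaks for a change in either direction, and the step of a 1.0-fold lower number from compound 3 to compound 4 (0.00 log units; within the scatter) is expected to stay within the scatter. Among the measured compounds shown here, compound 4 is therefore estimated at 2000 nM, with a range from 600 nM to 7000 nM that is widened because no comparable step exists to anchor it.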

Compound 4, concentration for 50% growth inhibition: 3610 nM
For compound 4 the middle estimate is 1.8-fold (0.26 log units) below the measured one; low and high end bracket the measured number.
By their numbers in this assay, from the lowest: compounds 3, 1 and 4 (each within the scatter of the next); then compound 2.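

Within the data shown here, this is the first reading at the aromatic carbon of the five-membered aromatic ring with 2 nitrogen, as every earlier step concerned the aryl group on the double-bonded chain. In this assay, 3,4,5-trimethoxyphenyl in place of phenyl gives a 1.8-fold higher number from compound 3 to compound 4 (0.25 log units; within the scatter), so this position accepts a group of 12 heavy atoms with 3 hydrogen-bond acceptors in place of one of 6 heavy atoms with none, with no change that can be told from the scatter. Nothing available accounts for this outcome.

From the compounds shown here alone, the position rests on this single pair, so it remains open whether a phenyl carrying an amine or a carboxylic acid, or a methyl group in place of the ring, would behave the same way. Going by these compounds, it is also open whether 3,4,5-trimethoxyphenyl would give a similar result alongside the 3-hydroxyphenyl group on the chain.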